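Removing an ortho chloro from a weak antiproliferative pyridazinone amide

The source may hold more compounds than are shown below. What is called first, only, known or untested is meant among the compounds shown, and "the series" means these compounds.

The account follows two measured compounds and one not yet measured in a functional assay on MCF7 cells (Homo sapiens) for antiproliferative activity, read by MTT assay, with a stated time of 72 h; on this read-out lower numbers stand for stronger inhibition and higher numbers for weaker inhibition. Compound 1, `CNC(=O)c1cc(Oc2ccc(NC(=O)c3nn(-c4ccccc4Cl)c(=O)cc3C)cc2F)ccn1`, gives 136000 nM, the highest of the two numbers available here, so it is the weaker of the two on this read-out. Compound 2, `CCNC(=O)c1cc(Oc2ccc(NC(=O)c3nn(-c4ccc(C)cc4)c(=O)cc3C)cc2)ccn1`, differs from compound 1 in more than one place. In this assay compound 2 gives 51300 nM, a number beyond the scatter from that of compound 1. Two places change at once between these two compounds, so nothing can be drawn from this pair about either change alone.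

Compound 3, `CNC(=O)c1cc(Oc2ccc(NC(=O)c3nn(-c4ccccc4)c(=O)cc3C)cc2F)ccn1`, is compound 1 with one change: hydrogen in place of chloro on an aromatic carbon. Within the data shown here, no pair measured here isolates this change, so the expectation rests on compound 1 alone. A single chlorine leaving without a new group entering is expected to move this assay only a little, within or near the scatter, with a slight lean toward a lower number. Compound 3 is therefore expected to give 100000 nM, within a range from 40000 nM to 250000 nM, which means an expected step of a 1.4-fold lower number from compound 1 to compound 3 (0.13 log units; within the scatter).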

Compound 3, half-maximal inhibitory concentration: "not active" (no number reported)
For compound 3 the study gives words and no number; no gap can be computed for the estimate.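

In this assay, among these compounds, compound 3 is reported only in words, as not active, so no step from compound 1 to compound 3 can be read. Nothing shown here offers an explanation for this result. The compounds shown leave open how far the change from 2-chlorophenyl to phenyl moves this read-out on the core of compound 1.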